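Fluoro for methyl on a limit-bound analogue

The compounds below may be only part of what the source reports. "The series", "measured", "known", "first", "only" and "open" are said of these compounds alone.

Measured so far in a functional assay on HeLa cells (Homo sapiens) for antiproliferative activity, read by MTT assay, with a stated time of 48 h; a lower number here means a stronger inhibitor, a higher number a weaker inhibitor:
compound 1 `CS(=O)(=O)c1ccc(Nc2ncc(F)c(Nc3nc4ccccc4s3)n2)cc1` — 3170 nM
compound 2 `Cc1cnc(Nc2ccc(S(C)(=O)=O)cc2)nc1Nc1nc2ccccc2s1` — 460 nM
compound 3 `Cc1cnc(Nc2ccc(S(C)(=O)=O)cc2)nc1Nc1nc2ccc(F)cc2s1` — > 50000 nM

In this assay compound 3 gives > 50000 nM, which is a limit of the assay and not a number, matching (the limit of > 50000 nM in this assay, at which 1 of the 3 values shown sits). The step to it from compound 2 was an at least 100-fold higher number from compound 2 to compound 3 (2.03 log units; beyond the scatter), so compound 3 stands at the top edge of what the series has shown.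

Compound 4 `CS(=O)(=O)c1ccc(Nc2ncc(F)c(Nc3nc4ccc(F)cc4s3)n2)cc1` has not been measured. It differs from compound 3 by fluoro in place of methyl on an aromatic carbon. Among the compounds with values here, the one measured step that bears on this exchange runs the other way: a 6.9-fold lower number from compound 1 to compound 2 (0.84 log units; beyond the scatter), where methyl replacing fluoro gave the lower number. Read in reverse, fluoro replacing methyl should raise the number by a modest amount. Compound 3 already reports only a limit. Compound 4 is therefore expected to return a limit as well, with the expected step that the limit leaves unreadable from compound 3 to compound 4 carrying little weight. Compound 4 is estimated at 150000 nM, with a range of 30000 nM to 800000 nM.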

Compound 4, half-maximal inhibitory concentration: > 50000 nM
Compound 4: a limit, no number (the forecaster's own chance of this, stated with the estimate: 85%); the middle value lies beyond the limit too.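

In this assay, the exchange of methyl for fluoro on the six-membered aromatic ring with 2 nitrogen cannot be sized once the second fluoro is present: compound 3 and compound 4 both report limits, and the step between them cannot be read. Fluoro in place of hydrogen on an aromatic carbon now has a second case, an at least 15-fold higher number from compound 1 to compound 4 (1.19 log units; beyond the scatter), so the same direction appears on both cores: the same change on two cores in this assay, an at least 100-fold higher number (2.03 log units; beyond the scatter) from compound 2 to compound 3 and an at least 15-fold higher number (1.19 log units; beyond the scatter) from compound 1 to compound 4; the limit leaves it open whether they differ A second compound now reaches the limit of the assay: the limit of > 50000 nM in this assay, at which 2 of the 4 values shown sit.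

On these data alone, how far compound 3 and compound 4 lie beyond that limit remains open, and so does whether the gain from fluoro to methyl seen without the second fluoro persists with it. Also open, as far as these compounds go, is whether chloro or methoxy in place of the second fluoro would bring the series back to measurable numbers.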